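Side-chain sulfur groups on the shared core

The compounds below may be only part of what the source reports. "The series", "measured", "known", "first", "only" and "open" are said of these compounds alone.

Compound 1 `CCCCn1c(=N)sc2cc(OC(F)(F)F)ccc21` gives 10 mg/kg in a functional assay on the whole organism with Rattus norvegicus as the target; a higher number here means that more compound is needed for the effect, a lower number that less compound is needed. For compound 2 `COC(=O)Cn1c(=N)sc2cc(OC(F)(F)F)ccc21` the assay returned only a limit, > 10 mg/kg. For compound 3 `CN(C)S(=O)(=O)CCn1c(=N)sc2cc(OC(F)(F)F)ccc21` the assay likewise returned only a limit, > 10 mg/kg. Compound 3 thus stands at the limit shared by two of the three measured values (the limit of > 10 mg/kg in this assay, at which 2 of the 3 values shown sit). Compound 4 `CS(=O)(=O)CCCn1c(=N)sc2cc(OC(F)(F)F)ccc21` differs from compound 3 by (methylsulfonyl)methyl in place of dimethylsulfamoyl on a saturated chain carbon, two bonds along the chain from an aromatic nitrogen. Among the compounds with values here, the steps that bear on this change are a number no lower from compound 1 to compound 2 (the limit leaves the size open) and a number no lower from compound 1 to compound 3 (the limit leaves the size open), both no lower and of unreadable size, while a step that the two limits leave unreadable from compound 2 to compound 3 is unreadable as well. Within the data shown here, no measured step gives a readable size, so no shift beyond the scatter can be inferred in either direction, and a further limit is the more likely outcome. The step to compound 4 is expected as a step that the limit leaves unreadable from compound 3 to compound 4. Compound 4 is therefore estimated at 15 mg/kg, within 5 mg/kg to 50 mg/kg.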

Compound 4, dose for half-maximal effect: 5 mg/kg
Beside the measured number, compound 4's estimate is 3.0-fold (0.48 log units) above it, and the stated range covers the measured number.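

Within the data shown here, compound 4 is the first compound with a sulfur-bearing side chain to give a number rather than a limit in this assay, with an at least 2.0-fold lower number from compound 3 to compound 4 (0.30 log units; that floor lies within the scatter) on exchanging dimethylsulfamoyl for (methylsulfonyl)methyl. Against the methoxycarbonyl side chain the reading is an at least 2.0-fold lower number from compound 2 to compound 4 (0.30 log units; that floor lies within the scatter). Against the all-carbon chain, methylsulfonyl in place of methyl gives a 2.0-fold lower number from compound 1 to compound 4 (0.30 log units; within the scatter), so this place accepts the methylsulfonyl end with no shift shown beyond the scatter.

Going by these compounds, compound 3 remains a limit, > 10 mg/kg, so the true size of its step stays open. Also open, on these data alone, is whether a carboxylic acid or an amine at the chain end, or a longer chain carrying methylsulfonyl, would give a number in this assay.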